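A few compounds are considered here, and "the series" means these few. Any claim that something is new, unique, unknown or untested is made for them only; others in the source may bear on it.

Measured so far in a functional assay on MDA-MB-435 cells (Homo sapiens) for inhibition, read by CellTiter-Glo, with a stated time of 72 h; on this read-out lower numbers stand for stronger inhibition and higher numbers for weaker inhibition:
- compound 1 `COc1cc2ncnc(Oc3ccc(NC(=O)Nc4ccc(Cl)c(C(F)(F)F)c4)c4ccccc34)c2cc1OC`: 3790 nM
- compound 2 `COc1cc2ncnc(Oc3ccc(NC(=O)Nc4cnn(C(C)C)c4)c4ccccc34)c2cc1OC`: "not determined" (no result reported)
- compound 3 `COc1cc2ncnc(Oc3ccc(NC(=O)Nc4cc(C)on4)c4ccccc34)c2cc1OC`: "not determined" (no result reported)

Going by the values given here, only one compound in this small set carries a number. Compound 3 has none, and the same is true of compound 2, so compound 3 cannot be ranked against anything on the present data. Among the compounds with values here, no step between measured compounds is available either, and the series offers no trend to extend.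

Compound 4 `COc1cc2ncnc(Oc3ccc(NC(=O)NC4(C#N)CCCC4)c4ccccc34)c2cc1OC` is the next to be read. It keeps the shared core and the urea-type linkage of compound 3, with 1-cyanocyclopentyl in place of 5-methyl-1,2-oxazol-3-yl on an amide-type nitrogen.

The size of this step cannot be derived from the data, since its starting point has no number. The only anchor in this assay is compound 1 at 3790 nM. Against that anchor, a modest shift towards weaker inhibition is expected, though a result within the usual scatter would not be surprising. The confidence is low, as it rests on a single measured compound. For compound 4 the expected value is 6000 nM, with an estimated range of 1500 nM to 20000 nM.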

Compound 4, half-maximal inhibitory concentration: 3010 nM
For compound 4 the middle estimate is 2.0-fold (0.30 log units) above the measured one, within the range that was stated.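

In this assay, the amide-type nitrogen whose other neighbour is the carbonyl carbon now has two groups with a number, and 1-cyanocyclopentyl in place of 4-chloro-3-(trifluoromethyl)phenyl gives a 1.3-fold lower number from compound 1 to compound 4 (0.10 log units; within the scatter) at this position. On this single pair, a five-membered non-aromatic ring of carbon only bearing a nitrile cannot be told apart from the chlorinated, trifluoromethyl-bearing phenyl group, so an aromatic ring on this nitrogen is not required to reach a number of this size in this read-out. The steps from compound 2 and compound 3 cannot be read, as neither compound has a number, and no measured property bears on the result.

Going by these compounds alone, with only two numbers, it remains open whether the outer group at this nitrogen has any influence on this read-out, or whether the shared core sets the level seen for both compounds. A plain cyclopentyl without the nitrile, a carboxylic acid or an amine in the nitrile's place, and a longer alkyl chain on the same nitrogen would each test this, and the compounds shown contain none of these groups.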